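This account rests on a few compounds, and the source may have more. Where it says the series, first, only, none or still open, it means among the compounds named here.

Working notes on the series.

Compound 3 `C=CC1=C(C(=O)NCCCCC)C(c2ccc(OC)cc2)OC1` is one of three analogues of the shared core examined in a functional assay on HeLa cells (Homo sapiens) for cytotoxicity, read by MTT assay, with a stated time of 24 h; on this read-out higher numbers stand for weaker inhibition and lower numbers for stronger inhibition. In this assay compound 3 reaches only a limit, > 100000 nM, and not a number. Compound 1 `C=CC1=C(C(=O)Nc2ccccc2)C(c2ccc(OC)cc2)OC1` likewise gives a limit, > 100000 nM. Compound 2 `C=CC1=C(C(=O)NCCCCC)C(c2ccc(F)cc2)OC1` also gives a limit, > 100000 nM. The two single-point changes within the measured set, a step that the two limits leave unreadable from compound 1 to compound 3 and a step that the two limits leave unreadable from compound 2 to compound 3, are therefore unreadable in size, because of the limit of > 100000 nM in this assay, at which 3 of the 3 values shown sit.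

Compound 4 `C=CC1=C(C(=O)NCc2ccc(C)cc2)C(c2ccc(OC)cc2)OC1` differs from compound 3 by 4-methylphenyl in place of butyl on a saturated chain carbon bound to an amide-type nitrogen. Among the measured compounds shown here, no measured step in this assay bears directly on this change, and the two steps that are known give no readable size. The closest comparison, the exchange of an amide substituent in the unreadable step from compound 1 to compound 3, left both partners at the limit. The expectation is therefore that this change also produces no step beyond the scatter, with the expected step being a step that the limit leaves unreadable from compound 3 to compound 4. Compound 4 is thus estimated at 150000 nM, in a range of 30000 nM to 700000 nM, most probably again reported only as a limit.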

Compound 4, half-maximal inhibitory concentration: 15900 nM
Compound 4: the middle estimate sits 9.4-fold (0.97 log units) above what was measured; the whole stated range lies above it.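

In this assay, the substituent on the amide-type nitrogen is the one place in the series shown where a change gives a measured number: 4-methylphenyl in place of butyl gives an at least 6.2-fold lower number from compound 3 to compound 4 (0.79 log units; beyond the scatter), and 4-methylbenzyl in place of phenyl gives an at least 6.2-fold lower number from compound 1 to compound 4 (0.79 log units; beyond the scatter). An aromatic ring on that nitrogen is not enough by itself, as compound 1 carries phenyl there and still gives only a limit, > 100000 nM. Both steps are bounded on one side only and the earlier steps remain unreadable: the limit of > 100000 nM in this assay, at which 3 of the 4 values shown sit.

The compounds shown leave open whether the ring methyl of 4-methylbenzyl matters, which a plain benzyl or a 2-phenylethyl group on the nitrogen would address. Also open, on these data alone, is what fluoro in place of methoxy on the aromatic carbon does once 4-methylbenzyl sits on the nitrogen.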